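Series notes: trifluoromethyl removal from the pendant phenyl of compound 3

The source may report more compounds than this note shows. Statements on the series, on what has been measured and on what is new or still open speak of the compounds shown alone.

Measured compounds:
Compound 1 `COc1ccc(-c2ccc(C(=O)Nc3ccc(Oc4ccnc5[nH]ccc45)cc3)nc2)cc1` sits at the limit > 10000 nM in a functional assay on A549 cells (Homo sapiens) for cytotoxicity, read by MTT assay, with a stated time of 72 h; on this read-out higher numbers stand for weaker inhibition and lower numbers for stronger inhibition.
Compound 2 `O=C(Nc1ccc(Oc2ccnc3[nH]ccc23)cc1)c1ccc(-c2ccc(F)cc2F)cn1` sits at the limit > 10000 nM in this assay.
Compound 3 `O=C(Nc1ccc(Oc2ccnc3[nH]ccc23)cc1)c1cc(-c2ccc(C(F)(F)F)cc2)ccn1` gives 3950 nM in this assay.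

Within the data shown here, compound 3 is the only member of the series with a number in this assay; the other two values are limits, as set out in the limit of > 10000 nM in this assay, at which 2 of the 3 values shown sit. Among the measured compounds shown here, the only measured step, a step that the two limits leave unreadable from compound 1 to compound 2, runs between two limits and its size cannot be read. Compound 4 `O=C(Nc1ccc(Oc2ccnc3[nH]ccc23)cc1)c1cc(-c2ccccc2)ccn1` differs from compound 3 by hydrogen in place of trifluoromethyl on an aromatic carbon. For the measured compounds named here, no measured step removes a trifluoromethyl, so nothing indicates the direction of this change. With the shared core held and only the pendant phenyl altered, the estimate for compound 4 rests on compound 3 at 3950 nM, and the step of a 1.5-fold higher number from compound 3 to compound 4 (0.18 log units; within the scatter) is expected to stay within the usual scatter. Compound 4 is therefore estimated at 6000 nM, within 2500 nM to 15000 nM, with a fair chance that only a limit is reported.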

Compound 4, half-maximal inhibitory concentration: 2920 nM
Compound 4: middle estimate off by 2.1-fold (0.31 log units), on the high side; the range from low to high includes it.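

In this assay, among these compounds, the change from 4-(trifluoromethyl)phenyl to phenyl gives a 1.4-fold lower number from compound 3 to compound 4 (0.13 log units; within the scatter), the first step that can be read with a number at both ends. At this place, on an aromatic carbon para to a large group, hydrogen and trifluoromethyl are therefore not separated by this read-out. Compound 1 and compound 2 remain limits rather than numbers, and the step between them cannot be read: the limit of > 10000 nM in this assay, at which 2 of the 4 values shown sit.

Going by these compounds, whether another group on the same carbon, such as an amine or a carboxylic acid, would separate from hydrogen and trifluoromethyl remains open. Also open, on these data alone, is whether the phenyl itself could give way to an ethyl chain with the number held.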